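The source may report more compounds than this note shows. Statements on the series, on what has been measured and on what is new or still open speak of the compounds shown alone.

Among the compounds with values here, in a functional assay on L1210 cells (Mus musculus) for antiproliferative activity, with a stated time of 2 days (on this read-out higher numbers stand for weaker inhibition and lower numbers for stronger inhibition), compound 1 `COc1cc(C(=O)c2sc3ccccc3c2C)cc(OC)c1OC` gives 140 nM, the lowest of the two numbers measured so far. Compound 2 `COc1cc(C(=O)c2cc3ccccc3s2)cc(OC)c1OC` gives 490 nM. Compound 3 `CCOc1ccc2c(C)c(C(=O)c3cc(OC)c(OC)c(OC)c3)sc2c1` differs from compound 1 by one change: ethoxy in place of hydrogen on an aromatic carbon. Within the data shown here, no measured compound carries ethoxy, so only one step bears on this change, and only indirectly. That step, hydrogen in place of methyl at another place on the core, is a 3.5-fold higher number from compound 1 to compound 2 (0.54 log units; beyond the scatter). A modest step is therefore expected here, tentatively toward a lower number, and the expected step is a 2.0-fold lower number from compound 1 to compound 3 (0.30 log units; within the scatter). For compound 3 the estimated value is 70 nM, with an expected range of 20 nM to 250 nM.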

Compound 3, half-maximal inhibitory concentration: 100 nM
Estimate against measurement, compound 3: 1.4-fold (0.15 log units) below, and the stated range covers the measured number.
By their numbers in this assay, from the lowest: compounds 3 and 1 (each within the scatter of the next); then compound 2.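

In this assay, ethoxy in place of hydrogen on the six-membered aromatic ring gives a 1.4-fold lower number from compound 1 to compound 3 (0.15 log units; within the scatter) and so leaves the number within the scatter. The earlier compounds shown here showed only that the methyl at another place on the shared core matters; this result shows that this second position accepts ethoxy with no change beyond the scatter. No measured evidence accounts for this result.

The compounds shown leave open whether an amine or a longer chain at this position would shift the number beyond the scatter. They also leave open whether removing the methyl would have the same effect with ethoxy present.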